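Pyrrole to Imidazole: What to Expect for Compound 4

The source may report more compounds than this note shows. Statements on the series, on what has been measured and on what is new or still open speak of the compounds shown alone.

compound 1 `Cc1cc(N2CCCC2)c2ncc(CSCCc3ccccc3)n2c1`: > 100 ug/mL in an ADME assay on HEL cells (Homo sapiens) for cytotoxicity, with a stated time of 3 days (a higher number here means that more compound is tolerated, a lower number that less compound is tolerated), a limit of the assay
compound 2 `Cc1cc(N2CCCC2=O)c2ncc(CSCCc3ccccc3)n2c1`: 20 ug/mL
compound 3 `Cc1cc(-n2cccc2)c2ncc(CSCCc3ccccc3)n2c1`: 100 ug/mL

Compound 3 holds the higher of the two numbers that are numbers. Its nearest neighbour is compound 2, and the step of a 5.0-fold higher number from compound 2 to compound 3 (0.70 log units; beyond the scatter) lies beyond the scatter. Compound 1 sits at the limit (the limit of > 100 ug/mL in this assay, at which 1 of the 3 values shown sits), so the step of a number no higher from compound 1 to compound 3 (the limit leaves the size open) cannot be sized. Among the measured compounds shown here, the only other sized step, an at least 5.0-fold lower number from compound 1 to compound 2 (0.69 log units; beyond the scatter), runs toward less tolerance when 2-oxopyrrolidin-1-yl replaces pyrrolidin-1-yl.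

Compound 4 `Cc1cc(-n2ccnc2)c2ncc(CSCCc3ccccc3)n2c1` differs from compound 3 by 1H-imidazol-1-yl in place of 1H-pyrrol-1-yl on an aromatic carbon. For the measured compounds named here, no measured step swaps one five-membered aromatic ring for another; the closest comparison is the step from compound 2 to compound 3, where a ring bearing a carbonyl gave way to 1H-pyrrol-1-yl and tolerance rose. 1H-imidazol-1-yl brings a second hydrogen-bond acceptor, as the carbonyl of compound 2 did, but the two groups are otherwise unlike, so in this assay a step of a 1.7-fold lower number from compound 3 to compound 4 (0.22 log units; within the scatter) is expected, most likely within or near the scatter, leaning toward somewhat less tolerance. Compound 4 is therefore estimated at 60 ug/mL, with a range from 20 ug/mL to 100 ug/mL.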

Compound 4, minimum cytotoxic concentration: 20 ug/mL
Compound 4: middle estimate off by 3.0-fold (0.48 log units), on the high side, within the range that was stated.
By their numbers in this assay, from the lowest: compounds 2 and 4 (each within the scatter of the next); then compound 3.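

In this assay, replacing 1H-pyrrol-1-yl with 1H-imidazol-1-yl on this aromatic carbon keeps the heavy-atom count and exchanges one ring carbon for a nitrogen, yet it gives a 5.0-fold lower number from compound 3 to compound 4 (0.70 log units; beyond the scatter), so an exchange between two five-membered aromatic rings is enough to move the number at this position. Two unlike groups also meet here, with no change at the digits printed from compound 2 to compound 4 (within the scatter), while the comparison with the saturated ring gives an at least 5.0-fold lower number from compound 1 to compound 4 (0.69 log units; beyond the scatter). Compound 1 stands at a limit of the assay: the limit of > 100 ug/mL in this assay, at which 1 of the 4 values shown sits.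

The compounds shown leave open whether the step follows the presence of a second ring nitrogen or where that nitrogen sits, a question that a 1H-pyrazol-1-yl group at this position would bear on directly, and a 1H-1,2,4-triazol-1-yl group would show whether a further ring nitrogen extends the step. They also leave open whether the same exchange gives a step of this size when the phenylethyl thioether chain of the shared core is replaced by a shorter chain or by an amine.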